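A Methyl Group Added to Compound 3

The source may report more compounds than this note shows. Statements on the series, on what has been measured and on what is new or still open speak of the compounds shown alone.

For the measured compounds named here, in a functional assay on SW480 cells (Homo sapiens) for antiproliferative activity, with a stated time of 72 h (on this read-out higher numbers stand for weaker inhibition and lower numbers for stronger inhibition), compound 3 `O=C(COc1ccc(CNC2CC=C(c3c[nH]c4ccccc34)CC2)c(F)c1)NO` gives 1150 nM as the highest number of the three measured so far, with compound 2 `Cc1[nH]c2ccccc2c1C1=CCC(NCc2ccc(OCC(=O)NO)cc2)CC1` at 367 nM and compound 1 `O=C(COc1ccc(CNC2CC=C(c3c[nH]c4ccc(F)cc34)CC2)c(F)c1)NO` at 179 nM on the stronger side. Compound 4 `Cc1[nH]c2ccccc2c1C1=CCC(NCc2ccc(OCC(=O)NO)cc2F)CC1` is still unmeasured. It differs from compound 3 by methyl in place of hydrogen on an aromatic carbon, 1H-indol-3-yl becoming 2-methyl-1H-indol-3-yl, with methyl in place of hydrogen on an aromatic carbon as the counted change.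

Going by the values given here, no measured step isolates this change. Among the compounds with values here, the only single-place step, a 6.4-fold higher number from compound 1 to compound 3 (0.81 log units; beyond the scatter), is modest but beyond the scatter. Within the data shown here, it involves fluoro rather than methyl, so it shows only that one small swap can move the number. Compound 2 is the nearer guide: it already carries the 2-methyl-1H-indol-3-yl group and sits at 367 nM against the higher value of compound 3, yet those two differ in a second place as well.

A modest drop is therefore expected, and the estimated step is a 2.7-fold lower number from compound 3 to compound 4 (0.44 log units; beyond the scatter) with real uncertainty around it. For compound 4 the estimated value is 420 nM, with an expected range from 150 nM to 1100 nM.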

Compound 4, half-maximal inhibitory concentration: 170 nM
Beside the measured number, compound 4's estimate is 2.5-fold (0.39 log units) above it, within the range that was stated.
By their numbers in this assay, from the lowest: compounds 4 and 1 (each within the scatter of the next); then compound 2; then compound 3.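

The methyl on the carbon next to the ring nitrogen now has a measured size of its own: in this assay, the change gives a 6.8-fold lower number from compound 3 to compound 4 (0.83 log units; beyond the scatter). The fluoro also still counts once this methyl is present, with a 2.2-fold lower number from compound 2 to compound 4 (0.33 log units; beyond the scatter), while a 1.1-fold lower number from compound 1 to compound 4 (0.02 log units; within the scatter) places the 2-methyl-1H-indol-3-yl and 5-fluoro-1H-indol-3-yl compounds level with each other. The gain from a fluoro is not a fixed amount, as its removal costs different amounts on the two cores: the same change on two cores in this assay, a 6.4-fold higher number (0.81 log units; beyond the scatter) from compound 1 to compound 3 and a 2.2-fold higher number (0.33 log units; beyond the scatter) from compound 4 to compound 2, 3.0-fold (0.47 log units) apart, beyond the scatter of two such steps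

Only hydrogen and methyl are shown at this position, so the effect of an ethyl group, a chlorine atom or a methoxy group remains open. Also open, on these data alone, is whether 5-fluoro-2-methyl-1H-indol-3-yl, which combines both changes, would lower the number further.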